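Cytotoxicity of a Benzamide Series: From Nitro to Dimethyl

The source may hold more compounds than are shown below. What is called first, only, known or untested is meant among the compounds shown, and "the series" means these compounds.

Compound 1 `Cc1cc(S(N)(=O)=O)ccc1NC(=O)COc1ccc(Cl)cc1NC(=O)c1cccc(Cl)c1`: 59700 nM
Compound 2 `Cc1cc(S(N)(=O)=O)ccc1NC(=O)COc1ccc(Cl)cc1NC(=O)c1cccc(F)c1`: 243000 nM
Compound 3 `Cc1cc(S(N)(=O)=O)ccc1NC(=O)COc1ccc(Cl)cc1NC(=O)c1cccc([N+](=O)[O-])c1`: 58800 nM

In a functional assay on C8166 cells (Homo sapiens) for cytotoxicity, read by MTT assay (a lower number here means that less compound is tolerated, a higher number that more compound is tolerated), compound 3 gives 58800 nM, level with compound 1 at 59700 nM, while compound 2 tolerates clearly more. Compound 4 `Cc1cc(C)cc(C(=O)Nc2cc(Cl)ccc2OCC(=O)Nc2ccc(S(N)(=O)=O)cc2C)c1` carries 3,5-dimethylphenyl in place of 3-nitrophenyl on a carbonyl carbon. Swaps on this same ring gave a 1.0-fold lower number from compound 1 to compound 3 (0.01 log units; within the scatter), which lies within the scatter, as well as a 4.1-fold higher number from compound 1 to compound 2 (0.61 log units; beyond the scatter) and a 4.1-fold lower number from compound 2 to compound 3 (0.62 log units; beyond the scatter), both modest. Among the compounds with values here, no measured compound carries the dimethyl group, so these steps are only a rough guide. A small rise, within the scatter, is therefore expected in this assay. The expected change is a 1.4-fold higher number from compound 3 to compound 4 (0.16 log units; within the scatter). For compound 4 the estimated value is 85000 nM, with an expected range of 35000 nM to 230000 nM.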

Compound 4, half-maximal cytotoxic concentration: 36500 nM
Compound 4: the middle estimate sits 2.3-fold (0.37 log units) above what was measured, within the range that was stated.
By their numbers in this assay, from the lowest: compounds 4, 3 and 1 (each within the scatter of the next); then compound 2.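

In this assay, the 3,5-dimethylphenyl group, which has no hydrogen-bond acceptors, is tolerated on this carbonyl carbon about as well as the 3-nitrophenyl (a 1.6-fold lower number from compound 3 to compound 4 (0.21 log units; within the scatter)) and 3-chlorophenyl (a 1.6-fold lower number from compound 1 to compound 4 (0.21 log units; within the scatter)) groups. The 3-fluorophenyl group remains the clear outlier (a 6.7-fold lower number from compound 2 to compound 4 (0.82 log units; beyond the scatter)). Nothing available explains these differences.

On these data alone, whether an amine, a carboxylic acid or a longer chain on the ring at this position would shift the tolerated concentration remains open. So does how a single methyl group would compare with two.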